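The compounds below may be only part of what the source reports. "The series", "measured", "known", "first", "only" and "open" are said of these compounds alone.

The measured values in a functional assay on MCF7 cells (Homo sapiens) for antiproliferative activity, read by MTT assay, with a stated time of 48 h (on this read-out lower numbers stand for stronger inhibition and higher numbers for weaker inhibition), are these:

Compound 1 `CCc1ccccc1-n1nncc1CN1C(=O)C2(C(C#N)=C(N)Oc3c(N)cc4nc5ccccc5nc4c32)c2ccccc21`: 24600 nM
Compound 2 `CCOc1ccccc1-n1nncc1CN1C(=O)C2(C(C#N)=C(N)Oc3c(N)cc4nc5ccccc5nc4c32)c2ccccc21`: > 50000 nM, which is a limit of the assay rather than a number.

Compound 2 thus sits at the weak end of what this assay can report, and the step of an at least 2.0-fold higher number from compound 1 to compound 2 (0.30 log units; that floor lies within the scatter) is known only as a floor, one that still lies within the scatter (the limit of > 50000 nM in this assay, at which 1 of the 2 values shown sits). Compound 3 `Cc1ccc(C)c(-n2nncc2CN2C(=O)C3(C(C#N)=C(N)Oc4c(N)cc5nc6ccccc6nc5c43)c3ccccc32)c1` differs from compound 2 by 2,5-dimethylphenyl in place of 2-ethoxyphenyl on an aromatic nitrogen. Among the measured compounds shown here, no measured step covers this exchange: the single measured step swaps ethyl for ethoxy, whereas here the ethoxy group gives way to two methyl groups, so compound 3 resembles compound 1 more than compound 2 in carrying only carbon on that ring. On that basis compound 3 is expected to fall near the two measured values, at 30000 nM with a likely range of 10000 nM to 80000 nM. The step of an at least 1.6-fold lower number from compound 2 to compound 3 (0.22 log units; that floor lies within the scatter) is expected to stay within the scatter, with a fair chance that only a limit is reported.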

Compound 3, half-maximal inhibitory concentration: > 50000 nM
Compound 3 was reported as a limit; the forecaster's own chance of this, stated with the estimate: 40%; middle value at least 1.6-fold (0.22 log units) away from the limit.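

In this assay compound 3 gives > 50000 nM which is a limit and not a number. Putting 2,5-dimethylphenyl in place of 2-ethylphenyl on the aromatic nitrogen gives an at least 2.0-fold higher number from compound 1 to compound 3 (0.30 log units; that floor lies within the scatter) and so shows that a second group, this one without the oxygen of 2-ethoxyphenyl, also yields no measurable number here, although that floor does not separate it from compound 1. The two groups in compound 2 and compound 3 cannot be ranked, and the step between these compounds cannot be read, because both values are limits: the limit of > 50000 nM in this assay, at which 2 of the 3 values shown sit.

From the compounds shown here alone, how much activity compound 2 and compound 3 actually have stays open. Also open, going by these compounds, is whether a plain phenyl, or a phenyl carrying an amine or a carboxylic acid, would give a readable number at this position.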